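The source may hold more compounds than are shown below. What is called first, only, known or untested is meant among the compounds shown, and "the series" means these compounds.

Measured so far in a functional assay on HepG2 cells (Homo sapiens) for antiproliferative activity, read by MTT assay, with a stated time of 48 h; on this read-out lower numbers stand for stronger inhibition and higher numbers for weaker inhibition:
compound 1 (`CCOc1ccc(NC(=O)Nc2cccc(CNc3nccnc3Cl)c2)cc1`) gives 7050 nM
compound 2 (`COc1ccc(NC(=O)Nc2cccc(CNc3nccnc3Cl)c2)cc1`) gives 12000 nM
compound 3 (`O=C(Nc1cccc(CNc2nccnc2Cl)c1)Nc1ccccc1F`) gives 10500 nM

Compound 3 at 10500 nM cannot be separated from the other two. Its gaps are a 1.1-fold lower number from compound 2 to compound 3 (0.06 log units; within the scatter) and a 1.5-fold higher number from compound 1 to compound 3 (0.17 log units; within the scatter) and no order can be read among the three.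

The next compound is compound 4 (`Cc1ccc(NC(=O)Nc2cccc(CNc3nccnc3Cl)c2)cc1`). The change from compound 3 is 4-methylphenyl in place of 2-fluorophenyl on an amide-type nitrogen and amounts to 4-methylphenyl in place of 2-fluorophenyl on an amide-type nitrogen. Among the measured compounds shown here, no measured compound carries 4-methylphenyl, so the group itself is untested.

The two measured steps at this same place are the ones already given for compound 3, and both stay within the scatter. For the measured compounds named here, the only other measured step is a 1.7-fold higher number from compound 1 to compound 2 (0.23 log units; within the scatter) and it also stays within the scatter. On the strength of a 1.5-fold higher number from compound 1 to compound 3 (0.17 log units; within the scatter) and a 1.1-fold lower number from compound 2 to compound 3 (0.06 log units; within the scatter) no step beyond the scatter is expected in this assay for this change.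

The expected step is a 1.1-fold lower number from compound 3 to compound 4 (0.04 log units; within the scatter) and no clear direction is implied. For compound 4 the estimate is 9500 nM with an expected range from 5000 nM to 18000 nM in this measurement.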

Compound 4, half-maximal inhibitory concentration: 11500 nM
Estimate against measurement, compound 4: 1.2-fold (0.08 log units) below; the range from low to high includes it.
By their numbers in this assay, from the lowest: compounds 1, 3, 4 and 2 (each within the scatter of the next).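

In this assay, 4-methylphenyl in place of 2-fluorophenyl on an amide-type nitrogen gives a 1.1-fold higher number from compound 3 to compound 4 (0.04 log units; within the scatter) and adds a fourth group at this place that cannot be separated from the others, so compound 1, compound 2, compound 3 and compound 4 still show no order. What is new is a ring substituent without oxygen: methyl in place of methoxy on an aromatic carbon gives a 1.0-fold lower number from compound 2 to compound 4 (0.02 log units; within the scatter), and methyl in place of ethoxy gives a 1.6-fold higher number from compound 1 to compound 4 (0.21 log units; within the scatter), so the methyl group reads the same as either alkoxy group within the scatter. Nothing measured here offers a reason for this flat result.

As far as these compounds go, whether any group on this phenyl ring can move the number beyond the scatter stays open, and a carboxylic acid, a dimethylamino group or a longer chain such as butoxy would test that. From the compounds shown here alone, the core of compound 1 is also common to all four compounds, so the effect of replacing its chlorine with hydrogen or methoxy remains unknown in this assay.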